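The source may hold more compounds than are shown below. What is called first, only, known or untested is meant among the compounds shown, and "the series" means these compounds.

Compound 1 `CCOC(=O)/C=C/C(=O)N(CC(N)=O)NC(=O)[C@@H]1CCCN1C(=O)C1(NC(C)=O)CC1` in an assay on isolated protein for inhibition of legumain (Mus musculus), read by fluorescence, with stated times of 30 s and 2.5 h; on this read-out lower numbers stand for stronger inhibition and higher numbers for weaker inhibition: 9.3 nM
Compound 2 `CCOC(=O)/C=C/C(=O)N(CC(N)=O)NC(=O)[C@@H]1CCCN1C(=O)C(NC(C)=O)=C(C)C` in this assay: 148 nM

Going by the values given here, compound 2 stands at the higher of the two numbers, and the only measured step is a 16-fold higher number from compound 1 to compound 2 (1.20 log units; beyond the scatter). Compound 3 `C#CC[C@H](NC(C)=O)C(=O)N1CCC[C@H]1C(=O)NN(CC(N)=O)C(=O)/C=C/C(=O)OCC` is not yet measured. It differs from compound 2 by a group of 8 heavy atoms (6 carbon, 1 nitrogen, 1 oxygen; no ring) in place of a group of 8 heavy atoms (6 carbon, 1 nitrogen, 1 oxygen; no ring), on a carbonyl carbon. That measured step sits on the same carbonyl carbon and was large, so the position clearly matters, but the entering group here is a third kind and its direction is not fixed by the data. Compound 3 is therefore expected to improve only moderately, a 4.2-fold lower number from compound 2 to compound 3 (0.63 log units; beyond the scatter), giving an estimated 35 nM with a range from 8 nM to 150 nM.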

Compound 3, half-maximal inhibitory concentration: 17 nM
Estimate against measurement, compound 3: 2.1-fold (0.31 log units) above, within the range that was stated.
By their numbers in this assay, from the lowest: compounds 1 and 3 (each within the scatter of the next); then compound 2.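

The result shows that this position does not need the three-membered ring for a low number in this assay: the group with no ring, with one double bond, one triple bond and a defined stereocentre, gives an 8.7-fold lower number from compound 2 to compound 3 (0.94 log units; beyond the scatter) and so is not tied to the weak result of compound 2. Set against the ring-bearing group, the same entering group gives a 1.8-fold higher number from compound 1 to compound 3 (0.26 log units; within the scatter) and lies within the scatter, so the two groups cannot be told apart here. Nothing measured explains these steps.
Which part of the entering group, the triple bond or the stereocentre, accounts for the step stays open. So does whether a saturated propyl chain or a four-membered carbon ring on this carbonyl carbon would give a comparable number.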